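Will a Longer Chain Change the Picture?

The compounds below may be only part of what the source reports. "The series", "measured", "known", "first", "only" and "open" are said of these compounds alone.

Measured in a functional assay on MCF7 cells (Homo sapiens) for antiproliferative activity, read by sulforhodamine B assay, with a stated time of 48 h; a lower number here means a stronger inhibitor, a higher number a weaker inhibitor:
- Compound 1 `CCCCc1ccc(NS(=O)(=O)c2ccc(N3CCNC3=O)cc2)cc1`: 770 nM
- Compound 2 `CCc1ccc(NS(=O)(=O)c2ccc(N3CCNC3=O)cc2)cc1`: 810 nM

For the measured compounds named here, compound 2 lies within the usual scatter of compound 1, the only other compound measured, so the two cannot be told apart. Compound 3 `CCCCCCCc1ccc(NS(=O)(=O)c2ccc(N3CCNC3=O)cc2)cc1` keeps the shared core and has pentyl in place of hydrogen on a saturated chain carbon, two bonds along the chain from an aromatic carbon.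

Going by the values given here, one measured step bears on this change. At the same carbon, hydrogen replaces ethyl in a 1.1-fold higher number from compound 1 to compound 2 (0.02 log units; within the scatter), which stays within the scatter. Among the compounds with values here, no measured compound carries a chain as long as heptyl, so this single step is a weak guide. In this assay, the expected result is a 1.1-fold higher number from compound 2 to compound 3 (0.05 log units; within the scatter), which is no change beyond the scatter. The estimated value for compound 3 is 900 nM, with an expected range of 300 nM to 3000 nM.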

Compound 3, half-maximal inhibitory concentration: > 1000 nM
Compound 3 gave a limit, no number (the forecaster's own chance of this, stated with the estimate: 5%); at least 1.1-fold (0.04 log units) between middle value and limit.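

In this assay compound 3, which carries the heptyl chain, gave > 1000 nM, and this is a limit of the assay, not a number. All that can be read from it are two floors, an at least 1.2-fold higher number from compound 2 to compound 3 (0.09 log units; that floor lies within the scatter) and an at least 1.2-fold higher number from compound 1 to compound 3 (0.11 log units; that floor lies within the scatter), so pentyl in place of hydrogen at this carbon is not shown to move the result beyond the scatter, nor shown to leave it unchanged. Compound 1 and compound 2 both gave numbers, whereas the longest chain shown gives only a floor on the size of its change: the limit of > 1000 nM in this assay, at which 1 of the 3 values shown sits.

From the compounds shown here alone, whether the true value of compound 3 lies beyond the scatter from the other two stays open. Also open, going by these compounds, is what an amine or a carboxylic acid at the end of the chain, or a chain longer than heptyl, would do at this place.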